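The compounds below may be only part of what the source reports. "The series", "measured", "known", "first", "only" and "open" are said of these compounds alone.

Measured so far in a functional assay on DU-145 cells (Homo sapiens) for cytotoxicity, read by CCK-8 assay and cell counting, with a stated time of 72 h; on this read-out lower numbers stand for stronger inhibition and higher numbers for weaker inhibition:

Compound 1 `COc1cc(OC)cc(-c2cc3ccccc3c(-c3cccc(OC)c3)n2)c1` gives > 50000 nM, which is a limit of the assay.
Compound 2 `COc1cc(OC)cc(-c2cc3ccccc3c(-c3cccc(N)c3)n2)c1` gives 13200 nM.
Compound 3 `COc1cccc(-c2nc(-c3ccc(OC)c(OC)c3)cc3cc(C)ccc23)c1` gives > 50000 nM, which is again a limit of the assay.

From compound 1 to compound 2 the change is amino in place of methoxy on an aromatic carbon, and it brought an at least 3.7-fold lower number from compound 1 to compound 2 (0.57 log units; beyond the scatter). The size of that step is only a lower bound, as compound 1 sits at the limit of > 50000 nM in this assay, at which 2 of the 3 values shown sit. Compound 3 and compound 1 carry different cores; the difference between the two cores is not broken down here. Compound 4 `COc1ccc(-c2cc3cc(C)ccc3c(-c3cccc(N)c3)n2)cc1OC` has not yet been measured; it stands to compound 3 exactly as compound 2 stands to compound 1, by the same change, (amino in place of methoxy on an aromatic carbon). Compound 4 is therefore expected to show roughly an at least 2.7-fold lower number from compound 3 to compound 4 (0.44 log units; beyond the scatter) in this assay, resting on an at least 3.7-fold lower number from compound 1 to compound 2 (0.57 log units; beyond the scatter) and on compound 3 sitting at its limit. Compound 4 is estimated at 18000 nM, with a range from 7000 nM to 50000 nM.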

Compound 4, half-maximal inhibitory concentration: 4190 nM
The estimate for compound 4 lay 4.3-fold (0.63 log units) above the measured number; measured number outside the range, below it.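

In this assay, amino in place of methoxy on an aromatic carbon carried over from the core of compound 1 to the core of compound 3, giving an at least 11-fold lower number from compound 3 to compound 4 (1.07 log units; beyond the scatter). Set side by side, the two steps run the same way: the same change on two cores in this assay, an at least 3.7-fold lower number (0.57 log units; beyond the scatter) from compound 1 to compound 2 and an at least 11-fold lower number (1.07 log units; beyond the scatter) from compound 3 to compound 4; the limit leaves it open whether they differ Both steps start from a compound sitting at a limit of the assay, so the series shows only the direction and a lower bound for each step, not that one core gains more from the change than the other: the limit of > 50000 nM in this assay, at which 2 of the 4 values shown sit.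

The compounds shown leave open whether a hydroxyl, a methylamino group or an acetamide in place of the amino group would read like the amino compounds. They also leave open how the change would carry to further cores.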